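Swapping the Butoxy-Bearing Ring for a Smaller One

A few compounds are considered here, and "the series" means these few. Any claim that something is new, unique, unknown or untested is made for them only; others in the source may bear on it.

Two relatives of this series have been tested so far. Compound 1 (`O=C(NNc1ccc(F)cc1)c1cccc(NS(=O)(=O)c2cnc(O)nc2O)c1`) gives > 20000 nM in a functional assay on A549 cells (Homo sapiens) for antiproliferative activity, read by MTT assay, with a stated time of 24 h (on this read-out lower numbers stand for stronger inhibition and higher numbers for weaker inhibition), and this is a limit of the assay, not a number. For the measured compounds named here, compound 2 (`CCCCOc1ccc(C(=O)NNC(=O)c2cccc(NS(=O)(=O)c3cnc(O)nc3O)c2)cc1`) gives 7760 nM as the only actual number so far, so there is no second measured value to rank it against.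

Compound 3 (`Cc1ccccc1C(=O)NNC(=O)c1cccc(NS(=O)(=O)c2cnc(O)nc2O)c1`) has not been measured yet. It shares the core of compound 2 but has 2-methylphenyl in place of 4-butoxyphenyl on a carbonyl carbon.

Going by the values given here, no measured pair shows what a swap like this does, so any forecast rests on very little. Among the compounds with values here, the only number in hand, the 7760 nM of compound 2 , belongs to a molecule carrying the 4-butoxyphenyl group that compound 3 gives up, so weaker inhibition seems the likelier direction. The expected step is a 1.9-fold higher number from compound 2 to compound 3 (0.29 log units; within the scatter) toward weaker inhibition, a modest change at most. Compound 3 could also turn out to be reported only as a limit. For compound 3 the estimated value is 15000 nM with an expected range from 6000 nM to 35000 nM in this assay when it is tested.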

Compound 3, half-maximal inhibitory concentration: 8010 nM
The estimate for compound 3 lay 1.9-fold (0.27 log units) above the measured number; the measured number falls inside the stated range.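

In this assay, the swap of 2-methylphenyl in place of 4-butoxyphenyl on a carbonyl carbon gives a 1.0-fold higher number from compound 2 to compound 3 (0.01 log units; within the scatter), so for these two compounds, going from 11 heavy atoms to 7 and losing the one oxygen leaves the read-out unchanged within the usual scatter. For the compounds shown here, the other step, (2-methylphenyl)carbonyl in place of 4-fluorophenyl on an amine nitrogen, gives an at least 2.4-fold lower number from compound 1 to compound 3 (0.39 log units; beyond the scatter), which is the first sign that a change at this end of the molecule can move the number beyond the scatter. Compound 1 is reported only as a limit and not a number, so this step has a minimum size and no exact one: the limit of > 20000 nM in this assay, at which 1 of the 3 values shown sits.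

Going by these compounds, what an amine or a carboxylic acid at this place on the carbonyl-bearing ring would do remains open, as does the effect of a much longer chain. On these data alone, it is also open whether any group here can bring the number well under those of compound 2 and compound 3, since the two very different groups seen so far sit within the scatter of each other.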